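From hydroxy to methyl: compound 3 to compound 4

A few compounds are considered here, and "the series" means these few. Any claim that something is new, unique, unknown or untested is made for them only; others in the source may bear on it.

In a functional assay on SiHa cells (Homo sapiens) for inhibition, read by sulforhodamine B assay (on this read-out lower numbers stand for stronger inhibition of growth and higher numbers for weaker inhibition of growth), compound 1 `COc1ccc(-c2ccc(-c3ccc(-c4nc5cc(C)ccc5[nH]4)cc3)cc2)cc1OC` gives 3510 nM, compound 2 `FC(F)(F)c1ccc(-c2ccc(-c3ccc(-c4nc5ccccc5[nH]4)cc3)cc2)cc1` gives 100000 nM and compound 3 `Oc1cccc2[nH]c(-c3ccc(-c4ccc(-c5ccc(C(F)(F)F)cc5)cc4)cc3)nc12` gives 3720 nM. Compound 3 therefore lies within the scatter of compound 1 and far from compound 2.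

Compound 4 `Cc1ccc2[nH]c(-c3ccc(-c4ccc(-c5ccc(C(F)(F)F)cc5)cc4)cc3)nc2c1` carries 5-methyl-1H-benzimidazol-2-yl in place of the 4-hydroxy-1H-benzimidazol-2-yl of compound 3 (5-methyl-1H-benzimidazol-2-yl in place of 4-hydroxy-1H-benzimidazol-2-yl on an aromatic carbon). Among the compounds with values here, the only measured step bearing on this change is a 27-fold lower number from compound 2 to compound 3 (1.43 log units; beyond the scatter), which is large and beyond the scatter, and compound 4 lacks that hydroxy. Within the data shown here, no measured pair isolates the methyl. Compound 1 has the same 5-methyl-1H-benzimidazol-2-yl and gives 3510 nM, but the rest of its structure differs, so it offers only weak support for any recovery. Most of the hydroxy step is thus expected to be lost, though not all of it.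

The expected change is a 5.4-fold higher number from compound 3 to compound 4 (0.73 log units; beyond the scatter), towards a higher number. For compound 4 the estimated value is 20000 nM, with an expected range from 4000 nM to 100000 nM.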

Compound 4, concentration for 50% growth inhibition: 33200 nM
For compound 4 the middle estimate is 1.7-fold (0.22 log units) below the measured one; measured number inside the range.
By their numbers in this assay, from the lowest: compounds 1 and 3 (each within the scatter of the next); then compound 4; then compound 2.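

In this assay, methyl in place of hydrogen also lowers the number, a 3.0-fold lower number from compound 2 to compound 4 (0.48 log units; beyond the scatter), but this gain falls well short of the hydroxy step, a 27-fold lower number from compound 2 to compound 3 (1.43 log units; beyond the scatter), so the substituent on the benzimidazole is not interchangeable: an 8.9-fold higher number from compound 3 to compound 4 (0.95 log units; beyond the scatter). With the 5-methyl-1H-benzimidazol-2-yl held constant, 4-(trifluoromethyl)phenyl in place of 3,4-dimethoxyphenyl gives a 9.5-fold higher number from compound 1 to compound 4 (0.98 log units; beyond the scatter), so the methyl alone does not carry the level of compound 1 over to the other end group. Nothing at hand explains the size of these steps.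

Hydroxy and methyl stand at different places on the ring in these compounds, so the effect of the group and that of its place remain unseparated. Also open, as far as these compounds go, is whether an amine or a carboxylic acid on the same aromatic carbon would follow the hydroxy or the methyl.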